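This account rests on a few compounds, and the source may have more. Where it says the series, first, only, none or still open, it means among the compounds named here.

Values measured in a functional assay on HepG2 cells (Homo sapiens) for antiproliferative activity, read by MTT assay, with a stated time of 24 h; a lower number here means a stronger inhibitor, a higher number a weaker inhibitor:

- compound 1 `Clc1ccccc1CSc1nnc(-c2ccc3c(c2)OCCO3)n1-c1ccccc1`: 970 nM
- compound 2 `Fc1ccc(CSc2nnc(-c3ccc4c(c3)OCCO4)n2-c2ccccc2)cc1`: 1020 nM
- compound 3 `Brc1cccc(CSc2nnc(-c3ccc4c(c3)OCCO4)n2-c2ccccc2)c1`: 5210 nM
- compound 4 `Brc1ccc(CSc2nnc(-c3ccc4c(c3)OCCO4)n2-c2ccccc2)cc1`: not yet measured

Of the three measured compounds, compound 3 has the highest number and is therefore the weakest inhibitor. Two measured steps lead to it: a 5.4-fold higher number from compound 1 to compound 3 (0.73 log units; beyond the scatter) and a 5.1-fold higher number from compound 2 to compound 3 (0.71 log units; beyond the scatter). Both are modest. Compound 1 and compound 2 sit close together, with a 1.1-fold higher number from compound 1 to compound 2 (0.02 log units; within the scatter).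

Compound 4 has the same atoms as compound 3, joined differently: 4-bromophenyl in place of 3-bromophenyl on a saturated chain carbon bound to a sulfur. In words, it has 4-bromophenyl in place of 3-bromophenyl on a saturated chain carbon bound to a sulfur. For the measured compounds named here, no measured step shows this exact change, so the evidence is indirect. Compound 4 keeps the bromine of compound 3, but its group is named like the 4-fluorophenyl of compound 2, which gives 1020 nM. Three compounds cannot show how much of a 5.1-fold higher number from compound 2 to compound 3 (0.71 log units; beyond the scatter) comes from the change of halogen and how much from its place on the ring. A partial return towards compound 2 therefore seems the most reasonable expectation in this assay. The expected step is a 2.4-fold lower number from compound 3 to compound 4 (0.37 log units; beyond the scatter). The estimated value for compound 4 is 2200 nM, with an expected range of 750 nM to 6500 nM.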

Compound 4, half-maximal inhibitory concentration: 7940 nM
For compound 4 the middle estimate is 3.6-fold (0.56 log units) below the measured one; measured number above the stated range.
By their numbers in this assay, from the lowest: compounds 1 and 2 (each within the scatter of the next); then compounds 3 and 4 (each within the scatter of the next).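

In this assay, putting 4-bromophenyl in place of 3-bromophenyl on the saturated chain carbon bound to a sulfur gives a 1.5-fold higher number from compound 3 to compound 4 (0.18 log units; within the scatter) and so, in this pair, the two bromophenyl groups cannot be told apart. For the compounds shown here, the halogen itself gives a clearer signal: bromo in place of fluoro on an aromatic carbon gives a 7.8-fold higher number from compound 2 to compound 4 (0.89 log units; beyond the scatter) as a change in one place, while 4-bromophenyl in place of 2-chlorophenyl gives an 8.2-fold higher number from compound 1 to compound 4 (0.91 log units; beyond the scatter) and thus puts both bromine compounds at higher numbers than the fluorine and chlorine compounds, with no compound here going against that. Nothing measured here explains this difference between the halogens.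

From the compounds shown here alone, what 4-chlorophenyl would give on the same carbon remains open, and with it whether chlorine or the place of the halogen on the ring accounts for how compound 1 compares with compound 4. Going by these compounds, it is also open how groups without a halogen, such as 4-methoxyphenyl or 4-aminophenyl, would compare in this assay with the halogen-bearing rings.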